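From 2-Chlorophenyl to 3-Chloropyridin-2-yl on Compound 1

The source may report more compounds than this note shows. Statements on the series, on what has been measured and on what is new or still open speak of the compounds shown alone.

Three compounds have so far been measured in a functional assay on Shh Light II cells (Mus musculus) for inhibition, read by a luciferase reporter; on this read-out lower numbers stand for stronger inhibition and higher numbers for weaker inhibition:

Compound 1 `O=C(Nc1ccccc1Cl)N1CCC(c2nc(-c3ccc4ccccc4n3)no2)CC1`: 510 nM
Compound 2 `CC(C)c1ccccc1NC(=O)N1CCC(c2nc(-c3ccc4ccccc4n3)no2)CC1`: 480 nM
Compound 3 `O=C(NCC1CCC1)N1CCC(c2nc(-c3ccc4ccccc4n3)no2)CC1`: 410 nM

Compound 1 gives the highest of these three numbers, but its distance to compound 2 a 1.1-fold lower number from compound 1 to compound 2 (0.03 log units; within the scatter) and to compound 3 a 1.2-fold lower number from compound 1 to compound 3 (0.09 log units; within the scatter) both lie within the usual scatter, so the three compounds cannot be told apart on these data. The step between the other two, a 1.2-fold lower number from compound 2 to compound 3 (0.07 log units; within the scatter), is likewise within the scatter.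

Compound 4 `O=C(Nc1ncccc1Cl)N1CCC(c2nc(-c3ccc4ccccc4n3)no2)CC1` has not yet been measured. It differs from compound 1 in one place: 3-chloropyridin-2-yl in place of 2-chlorophenyl on an amide-type nitrogen.

The measured steps bear on this only loosely. One replaces a chloro with isopropyl on the same aromatic ring, the two others remove the whole ring in favour of cyclobutylmethyl. None introduces a ring nitrogen. Yet all three steps are within the scatter, which suggests that this end of the shared core accepts quite different groups without a visible change in the read-out.

The step from compound 1 to compound 4 is therefore expected to be small, a 1.0-fold lower number from compound 1 to compound 4 (0.01 log units; within the scatter), with no clear direction. Compound 4 is estimated at 500 nM, within a range of 200 nM to 1200 nM.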

Compound 4, half-maximal inhibitory concentration: 2800 nM
For compound 4 the middle estimate is 5.6-fold (0.75 log units) below the measured one, and the stated range ends below it.
By their numbers in this assay, from the lowest: compounds 3, 2 and 1 (each within the scatter of the next); then compound 4.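

In this assay, for the compounds shown here, this position proves less forgiving than the earlier compounds suggested: replacing one ring carbon with a ring nitrogen, while the chloro stays, gives a 5.5-fold higher number from compound 1 to compound 4 (0.74 log units; beyond the scatter) and is the first step in the set that clearly exceeds the scatter. Compound 4 also stands apart from the other two, with a 5.8-fold higher number from compound 2 to compound 4 (0.77 log units; beyond the scatter) and a 6.8-fold higher number from compound 3 to compound 4 (0.83 log units; beyond the scatter) printed as steps beyond the scatter, whereas the much larger structural change of replacing the whole 2-chlorophenyl with cyclobutylmethyl gives only a 1.2-fold lower number from compound 1 to compound 3 (0.09 log units; within the scatter) and stays within it, so the size of a change at this amide-type nitrogen says little about the size of its effect. No measurement at hand explains why this single ring nitrogen has so clear an effect.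

As far as these compounds go, whether any ring nitrogen in this group would do the same remains open, and a pyridin-3-yl, pyridin-4-yl or pyrimidinyl group would bear on that question. Also open, from the compounds shown here alone, is whether the chloro matters once the ring nitrogen is present, which a plain pyridin-2-yl or a 3-methylpyridin-2-yl group could help to settle.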